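The compounds below may be only part of what the source reports. "The series", "measured", "known", "first", "only" and "open" are said of these compounds alone.

Measured so far:
Compound 1, `COc1cc(OC)c(OC)cc1/C=C/COC(=O)/C=C/c1ccc(OC)c(OC)c1OC` — 75%
Compound 2, `COc1ccccc1/C=C/C(=O)OC/C=C/c1cc(OC)c(OC)cc1OC` — 100%

In a functional assay on the whole organism (strain Kunming) with Mus musculus as the target, with a stated time of 0.5 h, at a dose of 300 mg/kg by the intraperitoneal route (on this read-out higher numbers stand for a weaker effect at the one dose given and lower numbers for a stronger effect), compound 2 gives 100%, the highest of the two numbers shown, which here means the weaker effect. Its nearest neighbour is compound 1, whose value in this assay is lower by more than the usual scatter, so the two compounds are clearly apart on this read-out.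

Compound 3, `COc1cc(OC)c(OC)cc1/C=C/COC(=O)/C=C/c1cccc(Br)c1`, has not yet been measured. Its difference from compound 2 is 3-bromophenyl in place of 2-methoxyphenyl on a double-bonded chain carbon bound to a double-bonded chain carbon. Among the measured compounds shown here, no pair of measured compounds that differ in a single place is available, so no measured step tells how much such a change on this chain carbon may shift the value.

For compound 3 the expectation is therefore a modest downward step in this assay, shown as a number 15 percentage points lower from compound 2 to compound 3 (beyond the scatter), with wide uncertainty. Compound 3 is estimated at 85%, within a range from 60% to 100%.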

Compound 3, a percentage reported as activity, at one dose (the size of the read-out at that dose, not a potency): 50%
For compound 3 the middle estimate is 35 percentage points above the measured one; the measured number lies below the stated range.
By their numbers in this assay, from the lowest: compound 3; then compound 1; then compound 2.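

In this assay, among the compounds shown here, placing 3-bromophenyl in place of 2-methoxyphenyl on a double-bonded chain carbon bound to a double-bonded chain carbon gives a number 50 percentage points lower from compound 2 to compound 3 (beyond the scatter), the first single-place comparison in this set. This shows that the chain position is not indifferent: changing the aromatic group held there moves the read-out well beyond the usual scatter, towards a stronger effect at the one dose given. Nothing available here explains why this step is so large.

The change replaces one substituted phenyl group with another, so this one step cannot separate the contribution of adding bromine from that of removing methoxy. On these data alone, how an unsubstituted phenyl group, or a phenyl group carrying an amine or a carboxylic acid, would behave at this carbon also remains open.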